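Swapping Vinyl for Difluoromethyl on the Cyclopropane Ring

A few compounds are considered here, and "the series" means these few. Any claim that something is new, unique, unknown or untested is made for them only; others in the source may bear on it.

Compound 1 `COc1ccc2nc3c(nc2c1)O[C@H]1CN(C(=O)[C@H](C(C)(C)C)NC(=O)O[C@@H]2C[C@H]2CCCCC3)[C@H](C(=O)N[C@]2(C(=O)NS(=O)(=O)C3(C)CC3)C[C@H]2C(F)F)[C@@H]1C` gives 2.2 L/kg in an ADME assay (Rattus norvegicus) for pharmacokinetics; on this read-out higher numbers stand for wider distribution into tissues and lower numbers for narrower distribution.
Compound 2 `CC[C@@H]1[C@@H]2CN(C(=O)[C@H](C(C)(C)C)NC(=O)O[C@@H]3C[C@H]3CCCCCc3nc4ccc(OC)cc4nc3O2)[C@@H]1C(=O)N[C@]1(C(=O)NS(=O)(=O)C2(C)CC2)C[C@H]1C(F)F` gives 1.7 L/kg.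
Compound 3 `C=C[C@@H]1C[C@]1(NC(=O)[C@@H]1[C@H](CC)[C@@H]2CN1C(=O)[C@H](C(C)(C)C)NC(=O)O[C@@H]1C[C@H]1CCCCCc1nc3ccc(OC)cc3nc1O2)C(=O)NS(=O)(=O)C1CC1` gives 1.9 L/kg.

Compound 3 stands second highest of the three numbers, and its gaps to compound 2 and to compound 1 both lie within the scatter. Compound 4 `CC[C@@H]1[C@@H]2CN(C(=O)[C@H](C(C)(C)C)NC(=O)O[C@@H]3C[C@H]3CCCCCc3nc4ccc(OC)cc4nc3O2)[C@@H]1C(=O)N[C@]1(C(=O)NS(=O)(=O)C2CC2)C[C@H]1C(F)F` differs from it by difluoromethyl in place of vinyl on a saturated ring carbon. Going by the values given here, the only measured single step, a 1.3-fold lower number from compound 1 to compound 2 (0.11 log units; within the scatter), concerns a different place and says nothing about this exchange; no measured pair isolates difluoromethyl against vinyl. Compound 2, which carries difluoromethyl, and compound 3, which carries vinyl, lie within the scatter of each other, though they also differ elsewhere. A step of a 1.1-fold lower number from compound 3 to compound 4 (0.02 log units; within the scatter) is therefore expected, nothing beyond the scatter. Compound 4 is estimated at 1.8 L/kg, between 1 L/kg and 3.2 L/kg.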

Compound 4, volume of distribution at steady state: 1 L/kg
Estimate against measurement, compound 4: 1.8-fold (0.26 log units) above; the range from low to high includes it.
By their numbers in this assay, from the lowest: compounds 4, 2, 3 and 1 (each within the scatter of the next, the first and the last beyond it).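

Difluoromethyl in place of vinyl on this saturated ring carbon now has a direct reading in this assay, a step of a 1.9-fold lower number from compound 3 to compound 4 (0.28 log units; within the scatter) that separates the two groups by no more than the scatter. Hydrogen in place of methyl on a saturated ring carbon, a change in another place, gives a 1.7-fold lower number from compound 2 to compound 4 (0.23 log units; within the scatter) and also stays within the scatter. Nothing measured here offers a reason for either step. As far as these compounds go, whether an amine, a carboxylic acid or a longer chain on this ring carbon would move the number beyond the scatter remains open.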